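The source may hold more compounds than are shown below. What is called first, only, known or untested is meant among the compounds shown, and "the series" means these compounds.

Working notes on the quinoline-carboxylic acid amide series, continuing from compound 3.

Compound 3 `COc1cc(-c2cc(C(=O)O)c3ccccc3n2)ccc1OCC(=O)Nc1ccccc1C(F)(F)F` is the reference point. In an ADME assay on HaCaT cells (Homo sapiens) for inhibition (a lower number here means a stronger inhibitor, a higher number a weaker inhibitor), compound 3 gives 102000 nM, which is the smallest of the three numbers to hand. Compound 2 `COc1cc(-c2cc(C(=O)O)c3ccccc3n2)ccc1OCC(=O)Nc1cccc(F)c1` gives 148000 nM in this assay; the step of a 1.5-fold lower number from compound 2 to compound 3 (0.16 log units; within the scatter) is within the scatter, so compounds 2 and 3 are not separated by this read-out. Compound 1 `COc1cc(-c2cc(C(=O)O)c3ccccc3n2)ccc1OCC(=O)Nc1cccc(C)c1` gives 225000 nM in this assay; the step of a 2.2-fold lower number from compound 1 to compound 3 (0.34 log units; beyond the scatter) is beyond the scatter, though modest, and a 1.5-fold lower number from compound 1 to compound 2 (0.18 log units; within the scatter) is within the scatter.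

The next compound, compound 4 `COc1cc(-c2cc(C(=O)O)c3ccccc3n2)ccc1OCC(=O)NCc1cccs1`, carries the change ((thiophen-2-yl)methyl in place of 2-(trifluoromethyl)phenyl on an amide-type nitrogen). Both earlier steps that touched the group on the amide-type nitrogen, a 2.2-fold lower number from compound 1 to compound 3 (0.34 log units; beyond the scatter) and a 1.5-fold lower number from compound 2 to compound 3 (0.16 log units; within the scatter), moved the number little: one modest, one within the scatter. Within the data shown here, no measured step exchanges an aryl group for a (thiophen-2-yl)methyl group, so no direct precedent exists for the new entering group. On that basis the step of a 1.1-fold higher number from compound 3 to compound 4 (0.03 log units; within the scatter) in this assay is expected to stay small, most likely within the scatter, with no direction favoured. Compound 4 is therefore estimated at 110000 nM in this assay, with a range from 45000 nM to 270000 nM.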

Compound 4, half-maximal inhibitory concentration: > 300000 nM
Compound 4 gave a limit, no number; the forecaster's own chance of this, stated with the estimate: 10%; at least 2.7-fold (0.43 log units) between middle value and limit.
By their numbers in this assay, from the lowest: compounds 3, 2 and 1 (each within the scatter of the next, the first and the last beyond it). At a limit, above all of these: compound 4.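

In this assay, compound 4 gives a limit of the assay and not a number: the limit of > 300000 nM in this assay, at which 1 of the 4 values shown sits.

Even so, the exchange at the amide-type nitrogen gives an at least 2.9-fold higher number from compound 3 to compound 4 (0.46 log units; beyond the scatter), so this position is not indifferent to every replacement, as the small earlier steps among the three aryl amides might have suggested, and the (thiophen-2-yl)methyl group is the first entering group here to move the number upward beyond the scatter from compound 3. The comparisons with the other two aryl amides are looser, an at least 2.0-fold higher number from compound 2 to compound 4 (0.30 log units; that floor lies within the scatter) and an at least 1.3-fold higher number from compound 1 to compound 4 (0.12 log units; that floor lies within the scatter), and since both floors lie within the scatter, compound 3 is the only aryl amide shown to be firmly separated from compound 4.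

The change swaps the ring and adds a carbon link to the amide-type nitrogen in a single step, so the compounds shown cannot assign the shift to either part. As far as these compounds go, a benzyl group or a thiophen-2-yl group on that nitrogen would separate the two, and the true size of the step remains open while compound 4 stands at a limit.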